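The source may report more compounds than this note shows. Statements on the series, on what has been measured and on what is new or still open speak of the compounds shown alone.

Of the compounds shown here, two built on a shared core have been measured in a functional assay on A549 cells (Homo sapiens) for cytotoxicity, read by sulforhodamine B assay, with a stated time of 2 days, tested at 100 uM; on this read-out lower numbers stand for less inhibition and higher numbers for more inhibition at the one concentration tested (going by the name of the read-out). Compound 1, `O=C(Nn1c(-c2cccc([N+](=O)[O-])c2)nc2c(CCc3ccccc3)n[nH]c2c1=O)c1cccnc1`, carries a phenethyl group on the core and a pyridine amide; in this assay compound 1 gives 19%. Compound 2, `O=C(Nn1c(-c2cccc([N+](=O)[O-])c2)nc2c(-c3ccc(F)cc3)n[nH]c2c1=O)c1ccccc1`, carries instead a 4-fluorophenyl group and a plain benzene amide; in this assay compound 2 gives 80.7%. For the measured compounds named here, of the two numbers, compound 2 stands highest, and its only neighbour, compound 1, lies well beyond the scatter below it. Going by the values given here, these two compounds differ in more than one place, so no single step separates them.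

Compound 3, `O=C(Nn1c(-c2cccc([N+](=O)[O-])c2)nc2c(CCc3ccccc3)n[nH]c2c1=O)c1ccccc1`, is the next compound. It differs from compound 2 in one place: phenethyl in place of 4-fluorophenyl on an aromatic carbon. Compound 3 thus joins the phenethyl group of compound 1 with the amide of compound 2. Among the compounds with values here, no measured pair isolates this exchange, so the size of the step is uncertain. Because compound 1 gives 19% with the same phenethyl group, the expected step is a number 45.7 percentage points lower from compound 2 to compound 3 (beyond the scatter), a fall. For compound 3 the expected value in this assay is 35%, with a range from 10% to 65%.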

Compound 3, a percentage reported as inhibition, at one concentration (the size of the read-out at that concentration, not a potency): 73.9%
Estimate against measurement, compound 3: 38.9 percentage points below; measured number above the stated range.
By their numbers in this assay, from the lowest: compound 1; then compounds 3 and 2 (each within the scatter of the next).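

In this assay, phenethyl in place of 4-fluorophenyl on an aromatic carbon of the five-membered ring gives a number 6.8 percentage points lower from compound 2 to compound 3 (within the scatter), so with the benzene amide held constant, this read-out does not separate the two groups at this position. The large change appears at the amide instead: phenyl in place of pyridin-3-yl on a carbonyl carbon gives a number 54.9 percentage points higher from compound 1 to compound 3 (beyond the scatter), which ties the low number of compound 1 to its pyridine amide and not to its phenethyl group. Nothing available explains why the amide exchange matters so much here while the exchange on the ring does not.

For the compounds shown here, it remains open whether the pyridine amide would have the same effect alongside 4-fluorophenyl, since the amide exchange is seen only with phenethyl on the shared core. It is also unknown whether this position would accept a very different group, such as a carboxylic acid or an amine at the end of a longer chain, and how these compounds would compare at other concentrations in this assay.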